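Aryloxyacetamide thiazoles: expecting the fourth analogue

This account rests on a few compounds, and the source may have more. Where it says the series, first, only, none or still open, it means among the compounds named here.

Measured so far in a functional assay on MDA-MB-468 cells (Homo sapiens) for cytotoxicity, read by MTT assay, with a stated time of 48 h; a higher number here means a weaker inhibitor, a lower number a stronger inhibitor:
compound 1 `Cc1ccc(-c2csc(NC(=O)COc3ccc(Cl)c(C)c3)n2)cc1` — 54200 nM
compound 2 `Cc1cc(OCC(=O)Nc2nc(-c3ccc(Br)cc3)cs2)ccc1Cl` — 52100 nM
compound 3 `O=C(COc1ccc(F)cc1)Nc1nc(-c2ccc(Br)cc2)cs1` — 52100 nM

Compound 3 and compound 2 share the change (4-fluorophenyl in place of 4-chloro-3-methylphenyl on an oxygen on a saturated carbon); in this assay this gave no change at the digits printed from compound 2 to compound 3 (within the scatter). Compound 1 differs from compound 2 by methyl in place of bromo on an aromatic carbon, and that change gave a 1.0-fold higher number from compound 2 to compound 1 (0.02 log units; within the scatter). Compound 4 `Cc1ccc(-c2csc(NC(=O)COc3ccc(F)cc3)n2)cc1` has not yet been measured; it differs from compound 3 by methyl in place of bromo on an aromatic carbon, the same change at the same place as that from compound 2 to compound 1, and among these four compounds it occurs twice.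

The expectation for compound 4 rests on the earlier step, because a 1.0-fold higher number from compound 2 to compound 1 (0.02 log units; within the scatter). The step from compound 3 to compound 4 is therefore expected to be a 1.0-fold higher number from compound 3 to compound 4 (0.01 log units; within the scatter). Compound 4 is expected to give about 53000 nM, plausibly between 28000 nM and 100000 nM.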

Compound 4, half-maximal inhibitory concentration: 24900 nM
Estimate against measurement, compound 4: 2.1-fold (0.33 log units) above; measured number below the stated range.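

In this assay, methyl in place of bromo on the aromatic carbon gave a 2.1-fold lower number from compound 3 to compound 4 (0.32 log units; beyond the scatter), and this step does not differ reliably from its counterpart on the other core: the same change on two cores in this assay, a 1.0-fold higher number (0.02 log units; within the scatter) from compound 2 to compound 1 and a 2.1-fold lower number (0.32 log units; beyond the scatter) from compound 3 to compound 4, 2.2-fold (0.34 log units) apart, within the scatter of two such steps. The change from 4-chloro-3-methylphenyl to 4-fluorophenyl gave a 2.2-fold lower number from compound 1 to compound 4 (0.34 log units; beyond the scatter), and this step likewise stays close to its earlier counterpart: the same change on two cores in this assay, no change at the digits printed (within the scatter) from compound 2 to compound 3 and a 2.2-fold lower number (0.34 log units; beyond the scatter) from compound 1 to compound 4, 2.2-fold (0.34 log units) apart, within the scatter of two such steps. Each change therefore carried from one core to the other without a gap beyond the scatter, but two pairs per change cannot show that its size is the same on every core, or that it depends on the core.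

The compounds shown leave open what an amine or a carboxylic acid would do in the place held by bromo and methyl. They also leave open whether a longer chain there would give a number different from that of compound 4.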